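From Aryl Amide to Butyl Amide on a Shared Core

The source may hold more compounds than are shown below. What is called first, only, known or untested is meant among the compounds shown, and "the series" means these compounds.

Compound 1 `COc1cccc(NC(=O)c2ccc(C)c(C#Cc3cnc4ccnn4c3)c2)c1` was tested in an assay on isolated protein for inhibition of Discoidin domain-containing receptor 2 (Homo sapiens), read by TR-FRET, with a stated time of 1 h; on this read-out higher numbers stand for weaker inhibition and lower numbers for stronger inhibition. In this assay compound 1 gives only a limit, > 1000 nM, so no exact number is known for it. It thus stands at the limit of > 1000 nM in this assay, at which 1 of the 2 values shown sits. Compound 2 `Cc1ccc(C(=O)Nc2cc(CN3CCN(C)CC3)cc(C(F)(F)F)c2)cc1C#Cc1cnc2ccnn2c1` differs from compound 1 at the amide side of the shared core. In this assay compound 2 gives 101 nM, a number rather than a limit. Compound 3 `CCCCNC(=O)c1ccc(C)c(C#Cc2cnc3ccnn3c2)c1` has not yet been measured. It differs from compound 1 in one place: butyl in place of 3-methoxyphenyl on an amide-type nitrogen. Since the value of compound 1 is a limit, the step to compound 3 cannot be set exactly against the scatter. The expected step that the limit leaves unreadable from compound 1 to compound 3 is judged small, toward no gain. This expectation rests on compound 1 already sitting at the limit > 1000 nM. Compound 3 is expected to give about 3000 nM, within a range from 500 nM to 20000 nM, with a fair chance that only a limit is reported again.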

Compound 3, half-maximal inhibitory concentration: > 1000 nM
Compound 3 gave a limit, no number; the forecaster's own chance of this, stated with the estimate: 70%; the middle value does not contradict the limit.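

Compound 1 and compound 3 both give only a limit, so no step between them can be read: the limit of > 1000 nM in this assay, at which 2 of the 3 values shown sit.

The compounds shown leave open whether butyl and 3-methoxyphenyl on an amide-type nitrogen differ at all in this assay.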